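This account rests on a few compounds, and the source may have more. Where it says the series, first, only, none or still open, it means among the compounds named here.

Of the compounds shown here, three have been tested in a functional assay on the whole organism for inhibition, with Brassica napus as the target, with a stated time of 72 h, tested at 10 mg/L; on this read-out higher numbers stand for more inhibition of growth at the one concentration tested and lower numbers for less inhibition of growth. Compound 1, `CSc1cc(C)nc(NC(=S)NC(=O)c2c(-c3ccc(Cl)cc3Cl)noc2C)n1`, gives 42.4%. Compound 2, `Cc1cc(Cl)nc(NC(=S)NC(=O)c2c(-c3ccc(Cl)cc3Cl)noc2C)n1`, gives 8.36%. The two share a core and differ in one place: methylsulfanyl in place of chloro on an aromatic carbon. This change made a number 34 percentage points higher from compound 2 to compound 1 (beyond the scatter). Compound 3, `COc1cc(Cl)nc2n/c(=N/C(=O)c3c(-c4ccc(Cl)cc4Cl)noc3C)sn12`, is built on a different core; the difference between the two cores is not broken down here. In this assay compound 3 gives 28.6%, lower than compound 1 and higher than compound 2.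

Compound 4, `COc1cc(SC)nc2n/c(=N/C(=O)c3c(-c4ccc(Cl)cc4Cl)noc3C)sn12`, has not yet been measured. It differs from compound 3 by the same kind of change that separates compound 2 from compound 1: methylsulfanyl in place of chloro on an aromatic carbon. The surroundings are not identical, though: in compound 3 the carbon sits on a ring that is part of a fused or bridged system of two rings, meta to a fused ring, meta to a methoxy group and para to a fused ring, whereas in compound 2 it is meta to a large group and meta to a methyl group. Going by the values given here, because the only precedent gave a number 34 percentage points higher from compound 2 to compound 1 (beyond the scatter), a rise is expected here too, yet a somewhat smaller one, estimated as a number 21.4 percentage points higher from compound 3 to compound 4 (beyond the scatter), since only one example exists and the cores differ. Compound 4 is therefore expected to give about 50%, between 30% and 72%.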

Compound 4, percent growth inhibition at one concentration: 27.4%
For compound 4 the middle estimate is 22.6 percentage points above the measured one, and the stated range ends above it.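

In this assay, methylsulfanyl in place of chloro on the core of compound 3 gives a number 1.2 percentage points lower from compound 3 to compound 4 (within the scatter) and so leaves compound 3 and compound 4 indistinguishable on this read-out. The gain seen on the core of compound 1 therefore did not carry over to the core of compound 3, and the two cores responded differently to the same change: the same change on two cores in this assay, a number 34 percentage points higher (beyond the scatter) from compound 2 to compound 1 and a number 1.2 percentage points lower (within the scatter) from compound 3 to compound 4, 35.2 percentage points apart, beyond the scatter of two such steps. Going by these compounds alone, this does not show why the cores differ, and with only one example on each core it cannot say which feature of a core decides the outcome or whether either result would hold on further compounds.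

Going by these compounds, it remains open whether an amine or a nitrile at this aromatic carbon would also respond differently on the two cores. A longer chain on the sulfur, such as ethylsulfanyl, is also untested in the compounds shown, so its effect on the core of compound 3 is unknown, where compound 4, with methylsulfanyl, gives 27.4% in this assay.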